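The source may hold more compounds than are shown below. What is called first, only, known or untested is meant among the compounds shown, and "the series" means these compounds.

Going by the values given here, in a functional assay on SW-620 cells (Homo sapiens) for cytotoxicity, read by sulforhodamine B assay, with a stated time of 48 h (on this read-out lower numbers stand for stronger inhibition and higher numbers for weaker inhibition), compound 1 (`C[C@H]1CC[C@@H]2[C@@H](OC(=O)[C@]23CC(c2ccccc2[N+](=O)[O-])=NO3)[C@]2(C)C(=O)C=C[C@@]12O`) gives 40000 nM, while compound 2 (`COc1cc(C2=NO[C@]3(C2)C(=O)O[C@@H]2[C@H]3CC[C@H](C)[C@]3(O)C=CC(=O)[C@@]23C)ccc1O`) gives 88000 nM, the higher of the two numbers so far. Compound 3 (`C[C@H]1CC[C@@H]2[C@@H](OC(=O)[C@]23CC(c2ccccc2F)=NO3)[C@]2(C)C(=O)C=C[C@@]12O`) has 2-fluorophenyl in place of 4-hydroxy-3-methoxyphenyl on a carbon with a double bond to nitrogen. Among the compounds with values here, the one measured step at this place, a 2.2-fold higher number from compound 1 to compound 2 (0.34 log units; beyond the scatter), is modest and also involves 4-hydroxy-3-methoxyphenyl, so it is the only guide available, read in reverse. A modest fall in this assay is therefore expected: a 2.0-fold lower number from compound 2 to compound 3 (0.29 log units; within the scatter). For compound 3 the estimated value is 45000 nM, with an expected range of 18000 nM to 100000 nM.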

Compound 3, half-maximal inhibitory concentration: 11000 nM
Compound 3: the middle estimate sits 4.1-fold (0.61 log units) above what was measured, and the stated range ends above it.
By their numbers in this assay, from the lowest: compound 3; then compound 1; then compound 2.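

On the carbon with a double bond to nitrogen, the aryl group has more reach in this assay than the earlier step showed: 2-fluorophenyl gives an 8.0-fold lower number from compound 2 to compound 3 (0.90 log units; beyond the scatter) and puts compound 3 lowest of the three. A single exchange on the same aromatic carbon is enough for a clear shift, with fluoro in place of nitro giving a 3.6-fold lower number from compound 1 to compound 3 (0.56 log units; beyond the scatter) on the shared core. Nothing at hand explains either shift.

Still open, going by these compounds, is how unsubstituted phenyl or 2-aminophenyl would read at this carbon. With those groups, the series could show whether fluoro itself or merely the loss of the other groups sets the number.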